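A few compounds are considered here, and "the series" means these few. Any claim that something is new, unique, unknown or untested is made for them only; others in the source may bear on it.

Measured so far:
- compound 1 `CC1=C(C(=O)NC(C)C)C(c2ccco2)NC(=O)N1`: 2%
- compound 2 `CC1=C(C(=O)NC(C)C)C(c2ccsc2)NC(=O)N1`: 3%

In an assay on membranes from HEK293 cells for displacement of a labelled ligand from adenosine receptor A2b (Homo sapiens), read by scintillation counting, with a stated time of 30 min, tested at 1 uM (on this read-out higher numbers stand for more inhibition at the one concentration tested (going by the name of the read-out) and lower numbers for less inhibition), compound 1 gives 2%, the lowest of the two numbers shown. Its nearest neighbour is compound 2, which in this assay gives 3%. Going by the values given here, the one step between measured compounds, a number 1 percentage points higher from compound 1 to compound 2 (within the scatter), comes from thiophen-3-yl in place of furan-2-yl on a saturated ring carbon and stays within the scatter, so on these two compounds the read-out does not move.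

Compound 3 `CCC(CC)OC(=O)C1=C(C)NC(=O)NC1c1ccco1` has not yet been measured in this assay. The change from compound 1 is (pentan-3-yl)oxy in place of isopropylamino on a carbonyl carbon. Among the compounds with values here, no measured step concerns this carbonyl carbon or the groups on it; the only step available, from compound 1 to compound 2, changes a different part of the core and was flat. Nothing in the numbers therefore points to a move beyond the scatter in either direction. Compound 3 is expected to give 4%, within 0% to 20%, so that the expected step of a number 2 percentage points higher from compound 1 to compound 3 (within the scatter) remains within the scatter.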

Compound 3, a percentage reported as inhibition, at one concentration (the size of the read-out at that concentration, not a potency): 35%
Compound 3: the middle estimate sits 31 percentage points below what was measured; the whole stated range lies below it.
By their numbers in this assay, from the lowest: compounds 1 and 2 (each within the scatter of the next); then compound 3.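

In this assay, going by these compounds alone, the group on the carbonyl carbon is the first place where the read-out moves: there is a number 33 percentage points higher from compound 1 to compound 3 (beyond the scatter) with (pentan-3-yl)oxy in place of isopropylamino, while a number 1 percentage points higher from compound 1 to compound 2 (within the scatter) on the saturated ring carbon left it flat. This single exchange alters several things at once, as isopropylamino, with 4 heavy atoms and 1 hydrogen-bond donor, gives way to (pentan-3-yl)oxy, with 6 heavy atoms and 1 hydrogen-bond acceptor, so the step cannot be assigned to any one of these differences. No measurement at hand bears on why the number rises.

Still open, on these data alone, is whether the step follows the oxygen link or the pentan-3-yl chain, a question that (pentan-3-yl)amino and isopropoxy on the same carbonyl carbon would separate. Also open, as far as these compounds go, are how far the read-out climbs with a longer chain or cyclohexyloxy at this carbonyl carbon, and whether the step holds with thiophen-3-yl in place of furan-2-yl on the saturated ring carbon.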